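The compounds below may be only part of what the source reports. "The series", "measured", "known", "first", "only" and "open" are said of these compounds alone.

Three compounds sharing one core have been examined in a physicochemical assay for lipophilicity, measured as octanol-water partition, at pH 7.4; on this read-out higher numbers stand for higher lipophilicity and lower numbers for lower lipophilicity. Compound 1 `Cc1ccc(Cn2c(=O)[nH]c3c(N)nc(C(F)(F)F)cc32)cn1` gives 2.3 in this assay. Compound 2 `Nc1nc(C(F)(F)F)cc2c1[nH]c(=O)n2Cc1ccc(C(F)(F)F)nc1` gives "not determined" (no result reported) in this assay, so no number is known for it. Going by the values given here, compound 3 `COc1ccc(Cn2c(=O)[nH]c3c(N)nc(C(F)(F)F)cc32)cn1` gives 2.8 in this assay, the higher of the two numbers known, with compound 1 as its nearest neighbour. Among the compounds with values here, the only step between measured compounds is a number 0.50 log units higher from compound 1 to compound 3 (beyond the scatter), a modest rise that comes from methoxy in place of methyl on an aromatic carbon.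

Compound 4 `Nc1nc(C(F)(F)F)cc2c1[nH]c(=O)n2Cc1ccc(NCC2CC2)nc1` is the next compound to be measured in this assay. It differs from compound 3 by (cyclopropylmethyl)amino in place of methoxy on an aromatic carbon. The methoxy group that carried compound 3 upward in the step from compound 1 now leaves, and the step from compound 1 to compound 3 is therefore only a loose guide. The entering group is larger, with four carbons against one, but it also brings one hydrogen-bond donor that methoxy lacked. On balance a modest rise in this assay is expected, so compound 4 is estimated at 3.3, between 2.8 and 3.9, which would mean an expected step of a number 0.50 log units higher from compound 3 to compound 4 (beyond the scatter).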

Compound 4, distribution coefficient: 3.2
Beside the measured number, compound 4's estimate is 0.10 log units above it; measured number inside the range.
By their numbers in this assay, from the lowest: compound 1; then compound 3; then compound 4.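

In this assay, replacing methoxy with (cyclopropylmethyl)amino gives a number 0.40 log units higher from compound 3 to compound 4 (beyond the scatter), so a group that brings a hydrogen-bond donor, which methoxy lacks, still goes with a higher number at this place next to the ring nitrogen. Taken across the three groups with numbers at this one place, methyl, methoxy and (cyclopropylmethyl)amino, the values climb in that order, with a number 0.90 log units higher from compound 1 to compound 4 (beyond the scatter) overall, and no compound with a number goes against this order, though compound 2, with its trifluoromethyl group, cannot be placed in it. No measurement shown explains why the number moves with these changes.

The compounds shown leave open whether the cyclopropyl ring, the length of the chain or the linking nitrogen accounts for the step. A plain amine, an open butylamino chain and a cyclopropylmethoxy group at the same place would separate these three.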